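Swapping ethyl for pyrrolidinyl: a modest gain expected

The source may report more compounds than this note shows. Statements on the series, on what has been measured and on what is new or still open speak of the compounds shown alone.

Compound 1 `O=[N+]([O-])c1ccc2nc(-c3ccc(Cl)c(Cl)c3)[nH]c2c1`: in a functional assay for antagonist activity at Neuropeptides B/W receptor type 1 (Homo sapiens), read by cAMP accumulation (on this read-out higher numbers stand for weaker inhibition and lower numbers for stronger inhibition), compound 1 gives only the limit > 31600 nM.
Compound 2 `CCc1ccc(-c2nc3cc([N+](=O)[O-])ccc3[nH]2)cc1`: in this assay compound 2 gives 1020 nM.

Within the data shown here, compound 2 carries the only actual number in this assay. The other entry is the limit of compound 1 (the limit of > 31600 nM in this assay, at which 1 of the 2 values shown sits), and a limit is not a number. Compound 3 `O=[N+]([O-])c1ccc2[nH]c(-c3ccc(N4CCCC4)cc3)nc2c1` differs from compound 2 by pyrrolidin-1-yl in place of ethyl on an aromatic carbon. Among the measured compounds shown here, no measured pair differs in a single place, so the size of this step has no precedent here. The step of a 2.6-fold lower number from compound 2 to compound 3 (0.41 log units; beyond the scatter) is expected to be a modest gain, just beyond the scatter. Compound 3 is therefore estimated at 400 nM, within 80 nM to 3000 nM in this assay.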

Compound 3, half-maximal inhibitory concentration: 1810 nM
The estimate for compound 3 lay 4.5-fold (0.66 log units) below the measured number, and the stated range covers the measured number.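

In this assay, pyrrolidin-1-yl in place of ethyl on this aromatic carbon, para to a large group, gives a 1.8-fold higher number from compound 2 to compound 3 (0.25 log units; within the scatter). This position therefore takes a five-membered non-aromatic ring with a hydrogen-bond acceptor, and the two compounds cannot be told apart on this read-out. Nothing shown here accounts for this outcome.

On these data alone, whether any group at this position moves the number beyond the scatter stays open. A carboxylic acid, a primary amine or a longer alkyl chain there could still answer that.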